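Diethylcarbamoyl in place of ((methylcarbamoyl)amino)methyl on the shared core

The compounds below may be only part of what the source reports. "The series", "measured", "known", "first", "only" and "open" are said of these compounds alone.

Among the compounds with values here, in a functional assay with Oryctolagus cuniculus as the target (on this read-out higher numbers stand for weaker inhibition and lower numbers for stronger inhibition), compound 2 `CNC(=O)NCc1nc(-c2ccc(OC)cc2)c(-c2ccc(OC)cc2)s1` gives 22 nM, the only exact number so far. Compound 1 `COc1ccc(-c2nc(/N=C(\N)n3ccnc3)sc2-c2ccc(OC)cc2)cc1` is reported only as a limit, > 100 nM. Compound 3 `CCN(CC)C(=O)c1nc(-c2ccc(OC)cc2)c(-c2ccc(OC)cc2)s1` differs from compound 2 by diethylcarbamoyl in place of ((methylcarbamoyl)amino)methyl on an aromatic carbon, with diethylcarbamoyl in place of ((methylcarbamoyl)amino)methyl on an aromatic carbon. Within the data shown here, the single measured step, an at least 4.5-fold lower number from compound 1 to compound 2 (0.65 log units; beyond the scatter), shows that exchanging the group on this carbon can move the number, so a modest rise in this assay is expected, though this one step gives little guidance. The expected change is a 2.7-fold higher number from compound 2 to compound 3 (0.44 log units; beyond the scatter). Compound 3 is estimated at 60 nM, within a range of 12 nM to 300 nM.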

Compound 3, half-maximal inhibitory concentration: < 10 nM
Compound 3: only a limit was reported; the forecaster's own chance of this, stated with the estimate: 30%; middle value at least 6.0-fold (0.77 log units) from the limit.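

In this assay, diethylcarbamoyl in place of ((methylcarbamoyl)amino)methyl gives an at least 2.2-fold lower number from compound 2 to compound 3 (0.34 log units; beyond the scatter), so a group with no hydrogen-bond donors on this aromatic carbon still lowers the number. The same group, set against the ring-bearing group that leaves compound 1, gives an at least 10-fold lower number from compound 1 to compound 3 (1.00 log units; beyond the scatter). The value of compound 3 is a limit and not a number: the limit of < 10 nM in this assay, at which 1 of the 3 values shown sits.

From the compounds shown here alone, the true size of both steps therefore stays open. Going by these compounds, it also remains open whether a smaller amide such as dimethylcarbamoyl, or a carboxylic acid, on this carbon would keep the number this low.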